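Benzylic aryl swap on a shared piperazine amide core

This account rests on a few compounds, and the source may have more. Where it says the series, first, only, none or still open, it means among the compounds named here.

Compound 1 `Cc1ccccc1CN1CCN(C(=O)CN[C@H]2CCN(S(=O)(=O)Cc3ccccc3)C2)CC1` is one of three analogues built on a shared core and tested in a functional assay on K562 cells (Homo sapiens) for cytotoxicity, read by MTT assay, with a stated time of 48 h; on this read-out lower numbers stand for stronger inhibition and higher numbers for weaker inhibition. In this assay compound 1 gives 10200 nM, the second highest of the three numbers. Compound 2 `Cc1ccc(CN2CCN(C(=O)CN[C@H]3CCN(S(=O)(=O)Cc4ccccc4)C3)CC2)cc1` gives 8200 nM in this assay, and a 1.2-fold lower number from compound 1 to compound 2 (0.09 log units; within the scatter). Compound 3 `O=C(CN[C@H]1CCN(S(=O)(=O)Cc2ccccc2)C1)N1CCN(Cc2c(Cl)cccc2Cl)CC1` gives 28400 nM in this assay, and a 2.8-fold higher number from compound 1 to compound 3 (0.44 log units; beyond the scatter); likewise a 3.5-fold higher number from compound 2 to compound 3 (0.54 log units; beyond the scatter).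

Compound 4 `COc1cccc(CN2CCN(C(=O)CN[C@H]3CCN(S(=O)(=O)Cc4ccccc4)C3)CC2)c1` differs from compound 1 in one place: 3-methoxyphenyl in place of 2-methylphenyl on a saturated chain carbon bound to an amine nitrogen in a ring. Within the data shown here, no measured step carries a methoxy group, so the nearest guides are the two steps from compound 1. The step to compound 2 shows that exchanging one methylphenyl for another at this position stays within the scatter, while the step to compound 3 shows that a 2,6-dichlorophenyl at the same position weakens inhibition modestly. A single methoxyphenyl is expected to behave more like the former, so the estimated step is a 1.0-fold higher number from compound 1 to compound 4 (0.01 log units; within the scatter), with no change expected beyond the scatter. Compound 4 is therefore estimated at 10500 nM in this assay, within a range of 4500 nM to 25000 nM.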

Compound 4, half-maximal inhibitory concentration: 60800 nM
For compound 4 the middle estimate is 5.8-fold (0.76 log units) below the measured one, and the stated range ends below it.
By their numbers in this assay, from the lowest: compounds 2 and 1 (each within the scatter of the next); then compound 3; then compound 4.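

Among these compounds, at this position on a saturated chain carbon bound to an amine nitrogen in a ring, the aryl group matters more than the earlier compounds showed: in this assay the change to 3-methoxyphenyl gives a 6.0-fold higher number from compound 1 to compound 4 (0.78 log units; beyond the scatter) and also a 7.4-fold higher number from compound 2 to compound 4 (0.87 log units; beyond the scatter) in the same series. Both steps exceed those seen with 2,6-dichlorophenyl, and a 2.1-fold higher number from compound 3 to compound 4 (0.33 log units; beyond the scatter) makes compound 4 the weakest of the four, so the closeness of compound 1 and compound 2 does not extend to every single-substituted phenyl. No measured evidence here accounts for this result.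

The steps to compound 4 change both the substituent and its place on the phenyl ring, and these two changes cannot be told apart. As far as these compounds go, how a phenyl ring carrying an amine or a carboxylic acid would behave at this position also remains open.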